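A few compounds are considered here, and "the series" means these few. Any claim that something is new, unique, unknown or untested is made for them only; others in the source may bear on it.

Compound 1 `Cc1ccccc1-n1nncc1CN1C(=O)C2(C(C#N)=C(N)Oc3c2c2nc4ccccc4nc2c2ccccc32)c2ccccc21`: in an ADME assay on L02 cells (Homo sapiens) for antiproliferative activity, read by MTT assay, with a stated time of 48 h (on this read-out higher numbers stand for weaker inhibition and lower numbers for stronger inhibition), compound 1 gives > 50000 nM, which is a limit of the assay rather than a number.
Compound 2 `N#CC1=C(N)Oc2c(c3nc4ccccc4nc3c3ccccc23)C12C(=O)N(Cc1cnnn1-c1ccc(F)cc1)c1ccccc12`: in this assay compound 2 gives > 50000 nM, again a limit.
Compound 3 `N#CC1=C(N)Oc2c(N)cc3nc4ccccc4nc3c2C12C(=O)N(Cc1cnnn1-c1cccc(Br)c1)c1ccccc12`: in this assay compound 3 gives > 50000 nM, also a limit.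

Compound 3 therefore stands where the other two stand, at the limit of > 50000 nM in this assay, at which 3 of the 3 values shown sit, and none of the three has a number of its own that could be compared.

Compound 4 `Cc1ccc(-n2nncc2CN2C(=O)C3(C(C#N)=C(N)Oc4c(N)cc5nc6ccccc6nc5c43)c3ccccc32)cc1C` differs from compound 3 in one place: 3,4-dimethylphenyl in place of 3-bromophenyl on an aromatic nitrogen. Among the compounds with values here, the only measured step of a similar kind, an exchange of one aryl group on that same aromatic nitrogen, is a step that the two limits leave unreadable from compound 1 to compound 2; its size cannot be read because both of its ends sit at the limit of > 50000 nM in this assay, at which 3 of the 3 values shown sit. Within the data shown here, no measured step thus gives a size or a direction for the change from compound 3 to compound 4. The expectation rests only on this: three compounds of the shared core, with three different aryl groups on that nitrogen, all stop at the limit, so no step beyond the scatter can be anticipated.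

Compound 4 is accordingly expected to give about 80000 nM in this assay, in the range 40000 nM to 200000 nM, which means an estimated step that the limit leaves unreadable from compound 3 to compound 4 and most likely another limit rather than a number.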

Compound 4, half-maximal inhibitory concentration: > 50000 nM
Compound 4: only a limit was reported (the forecaster's own chance of this, stated with the estimate: 85%); the middle value does not contradict the limit.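

Compound 3 and compound 4 each give only a limit of the assay rather than a number, so no size or direction can be read for the exchange between them: the limit of > 50000 nM in this assay, at which 4 of the 4 values shown sit.

The compounds shown leave open how far past that limit each of the four lies, and whether any aryl group on that aromatic nitrogen would give a measurable value.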